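This account rests on a few compounds, and the source may have more. Where it says the series, first, only, none or still open, it means among the compounds named here.

Measured compounds: compound 1 `CCCCCCNC(=O)c1c(O)cc(C)oc1=O`, which in an ADME assay on L929 cells (Mus musculus, culture collection number NCTC 929) for cytotoxicity, read by MTT assay, with a stated time of 72 h (a higher number here means a weaker inhibitor, a lower number a stronger inhibitor), gives 196000 nM; compound 2 `CCCCCCCCCCCCCCNC(=O)c1c(O)cc(C)oc1=O`, for which this assay reports only a limit, > 200000 nM; and compound 3 `CCCCCCCCCCCCc1c(O)cc(C)oc1=O`, which in this assay gives 57200 nM.

Compound 2 thus stands at a limit of this assay rather than at a number, (the limit of > 200000 nM in this assay, at which 1 of the 3 values shown sits). Compound 4 `CCCCCCCNC(=O)c1c(O)cc(C)oc1=O` differs from compound 2 by hydrogen in place of heptyl on a saturated chain carbon, seven bonds along the chain from an amide-type nitrogen. Among the compounds with values here, the only measured step that bears on this change is the reverse one, an at least 1.0-fold higher number from compound 1 to compound 2 (0.00 log units; that floor lies within the scatter), which stayed within the scatter. The step expected for compound 4 in this assay, an at least 1.0-fold lower number from compound 2 to compound 4 (0.02 log units; that floor lies within the scatter), is therefore none beyond the scatter. Compound 4 is estimated at 190000 nM, between 90000 nM and 400000 nM, and the result might again be reported only as a limit.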

Compound 4, half-maximal inhibitory concentration: 187000 nM
Compound 4: the middle estimate sits 1.0-fold (0.01 log units) above what was measured; measured number inside the range.
By their numbers in this assay, from the lowest: compound 3; then compounds 4 and 1 (each within the scatter of the next). At a limit, above all of these: compound 2.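

In this assay, the added methyl gives a 1.0-fold lower number from compound 1 to compound 4 (0.02 log units; within the scatter) and so leaves the reading unmoved. Hydrogen in place of heptyl gives an at least 1.0-fold lower number from compound 2 to compound 4 (0.02 log units; that floor lies within the scatter) and this floor fixes no size for the change. Compound 2 stands at a limit and not at a number: the limit of > 200000 nM in this assay, at which 1 of the 4 values shown sits.

From the compounds shown here alone, whether an amine or a carboxylic acid in place of that methyl would move the number stays open.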